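This account rests on a few compounds, and the source may have more. Where it says the series, first, only, none or still open, it means among the compounds named here.

Measured so far in a functional assay on Ehrlich cells (Mus musculus) for cytotoxicity, read by trypan blue exclusion, with a stated time of 2 h, tested at 50 ug/mL; on this read-out lower numbers stand for a weaker effect and higher numbers for a stronger effect at the one concentration tested:
Compound 1 `N#CC1=C(NC(=O)C2CC2)N(c2ccc(S(N)(=O)=O)cc2)C2=C(C(=O)CCC2)C1c1ccc(Cl)cc1Cl` gives 40%.
Compound 2 `N#CC1=C(NC(=O)/C=C/c2ccccc2)N(c2ccc(S(N)(=O)=O)cc2)C2=C(C(=O)CCC2)C1c1ccc(Cl)cc1Cl` gives 40%.
Compound 3 `COc1cc(C(=O)NC2=C(C#N)C(c3ccc(Cl)cc3Cl)C3=C(CCCC3=O)N2c2ccc(S(N)(=O)=O)cc2)cc(OC)c1OC` gives 95%.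

Compound 3 stands highest of the three numbers, with compound 1 the nearest and compound 2 the furthest, each with a step beyond the scatter. The step of a number 55 percentage points higher from compound 1 to compound 3 (beyond the scatter) and the step of a number 55 percentage points higher from compound 2 to compound 3 (beyond the scatter) are both large, while the step of no change at the digits printed from compound 1 to compound 2 (within the scatter) shows that the cyclopropyl and 2-phenylethenyl amides give the same read-out within the scatter. So far only the 3,4,5-trimethoxyphenyl amide separates from the rest.

Compound 4 `CC(=O)CC(=O)NC1=C(C#N)C(c2ccc(Cl)cc2Cl)C2=C(CCCC2=O)N1c1ccc(S(N)(=O)=O)cc1` is the next member. It differs from compound 3 by 2-oxopropyl in place of 3,4,5-trimethoxyphenyl on a carbonyl carbon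

Among the measured compounds shown here, the steps that bear on this change are those in which the 3,4,5-trimethoxyphenyl group was set against a non-aromatic acyl group. Both were large and point the same way: removing that group cost the bulk of the read-out. The 2-oxopropyl group carries no ring and is small, like the cyclopropyl in compound 1. On this basis compound 4 is expected to fall back toward the level of compound 1, with a step of a number 50 percentage points lower from compound 3 to compound 4 (beyond the scatter) expected in this assay. Compound 4 is therefore estimated at 45%, with a range of 25% to 75%.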

Compound 4, a percentage reported as activity, at one concentration (the size of the read-out at that concentration, not a potency): 60%
Compound 4: middle estimate off by 15 percentage points, on the low side; the measured number falls inside the stated range.
By their numbers in this assay, from the lowest: compounds 1 and 2 (each within the scatter of the next); then compound 4; then compound 3.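

In this assay, the change to 2-oxopropyl shows that this carbonyl carbon supports an intermediate level as well as the two seen before: losing the 3,4,5-trimethoxyphenyl group costs much of the read-out (a number 35 percentage points lower from compound 3 to compound 4 (beyond the scatter)), but not all of it, as the group still stands above both cyclopropyl (a number 20 percentage points higher from compound 1 to compound 4 (beyond the scatter)) and 2-phenylethenyl (a number 20 percentage points higher from compound 2 to compound 4 (beyond the scatter)). An acyl group with no ring therefore lifts the read-out over compound 2, which carries an aromatic ring in this place, so among these four compounds the presence of a ring does not by itself set the level, and compound 2 goes against any such pattern. Nothing measured here accounts for this order among the amides.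

On these data alone, it remains open whether the ketone carbonyl of the 2-oxopropyl group matters or whether a plain propyl chain would give the same level, and how a terminal amine or carboxylic acid on such a chain would compare. On the aromatic side, the compounds shown do not tell whether an unsubstituted phenyl or a single methoxyphenyl would keep the level of compound 3.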